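A few compounds are considered here, and "the series" means these few. Any claim that something is new, unique, unknown or untested is made for them only; others in the source may bear on it.

Measured compounds in a functional assay on cells (Cancer cell lines, Homo sapiens) for cytotoxicity, read by sulforhodamine B assay, with a stated time of 48 h; on this read-out lower numbers stand for stronger inhibition of growth and higher numbers for weaker inhibition of growth:
- compound 1 `COc1ccc(OC)c(-c2cc(-c3ccccc3)nn2-c2ccc(S(=O)(=O)NC(C)=O)cc2)c1`: 12000 nM
- compound 2 `COc1ccc(OC)c(-c2cc(-c3ccc(Cl)cc3)nn2-c2ccc(S(=O)(=O)NC(C)=O)cc2)c1`: 3610 nM
- compound 3 `NS(=O)(=O)c1ccc(-n2nc(-c3ccccc3)cc2-c2cc(O)ccc2O)cc1`: 77600 nM

Compound 1 and compound 2 share a core and differ only by chloro in place of hydrogen on an aromatic carbon; that change gave a 3.3-fold lower number from compound 1 to compound 2 (0.52 log units; beyond the scatter). Compound 3 sits on a different core; the difference between the two cores is not broken down here, and in this assay compound 3 stands highest of the three measured numbers.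

Compound 4 `NS(=O)(=O)c1ccc(-n2nc(-c3ccc(Cl)cc3)cc2-c2cc(O)ccc2O)cc1` is not yet measured. It differs from compound 3 by chloro in place of hydrogen on an aromatic carbon, the same change, at the same kind of place, as from compound 1 to compound 2. Among the compounds with values here, on the one prior example, with compound 1 moving to compound 2 by a 3.3-fold lower number from compound 1 to compound 2 (0.52 log units; beyond the scatter), a step of similar size is expected here: a 3.2-fold lower number from compound 3 to compound 4 (0.51 log units; beyond the scatter). The estimate for compound 4 in this assay is 24000 nM, expected to fall between 9000 nM and 65000 nM.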

Compound 4, concentration for 50% growth inhibition: 13400 nM
The estimate for compound 4 lay 1.8-fold (0.25 log units) above the measured number; the measured number falls inside the stated range.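

In this assay, chloro in place of hydrogen on an aromatic carbon again lowered the number, with a 5.8-fold lower number from compound 3 to compound 4 (0.76 log units; beyond the scatter). Set beside the earlier step, the change carried from one core to the other with no gap that can be told apart: the same change on two cores in this assay, a 3.3-fold lower number (0.52 log units; beyond the scatter) from compound 1 to compound 2 and a 5.8-fold lower number (0.76 log units; beyond the scatter) from compound 3 to compound 4, 1.7-fold (0.24 log units) apart, within the scatter of two such steps. This rests on two pairs in a single assay, both phenyl to 4-chlorophenyl; it shows the step holding on these two cores only and sets no rule for other cores or explains the effect.

Still open, as far as these compounds go, is whether fluoro, methoxy or an amine at that place would move the number in the same way. Also open, from the compounds shown here alone, is what separates the core of compound 1 from the core of compound 3, as no single change between them appears here.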